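From formyl to methylsulfonyl on the shared core

This account rests on a few compounds, and the source may have more. Where it says the series, first, only, none or still open, it means among the compounds named here.

- compound 1 `CC1(COc2ccc(-c3ccc(C(F)(F)F)cc3)cc2)Cn2cc([N+](=O)[O-])nc2O1` gives > 64000 nM
- compound 2 `CC1(COc2ccc(OC(F)(F)F)cc2)Cn2cc(C=O)nc2O1` gives > 64000 nM

In an ADME assay on MRC5 cells (Homo sapiens) for cytotoxicity, read by fluorescence, with a stated time of 72 h (a higher number here means a weaker inhibitor, a lower number a stronger inhibitor), compound 2 reads > 64000 nM and that is a limit, not a number. Compound 1 reads > 64000 nM and that is also a limit. Among the compounds with values here, the series so far shows the limit of > 64000 nM in this assay, at which 2 of the 2 values shown sit, and no step between measured compounds. Compound 3 `CC1(COc2ccc(OC(F)(F)F)cc2)Cn2cc(S(C)(=O)=O)nc2O1` carries methylsulfonyl in place of formyl on an aromatic carbon and is otherwise compound 2. With only that limit to go on, no change beyond the scatter is expected in this assay for this swap. The step expected a number no higher from compound 2 to compound 3 (the limit leaves the size open) is no larger than the scatter. For compound 3 the expected value is 64000 nM (estimated range 30000 nM to 64000 nM)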

Compound 3, half-maximal inhibitory concentration: > 64000 nM
Compound 3: no number, only a limit; the forecaster's own chance of this, stated with the estimate: 80%; the middle value lies on the limit itself.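

In this assay, compound 2 and compound 3 both read only as limits, so no step can be read between them. The compounds shown leave open whether any change on the shared core gives a measurable value: the limit of > 64000 nM in this assay, at which 3 of the 3 values shown sit.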